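Aryl-halide sulfonylamidine series: alkylamino chain branching

The source may hold more compounds than are shown below. What is called first, only, known or untested is meant among the compounds shown, and "the series" means these compounds.

Measured so far in a functional assay (aorta) with Rattus norvegicus as the target; a higher number here means that more compound is needed for the effect, a lower number that less compound is needed:
compound 1 `CC(C)NC1=NS(=O)(=O)c2cc(Br)ccc2N1` gives 4.8 uM;
compound 2 `CCC(C)NC1=NS(=O)(=O)c2cc(Br)ccc2N1` gives 5.6 uM;
compound 3 `CCC(C)NC1=NS(=O)(=O)c2cc(I)ccc2N1` gives 1.3 uM.

The change methyl in place of hydrogen on a saturated chain carbon, two bonds along the chain from an amine nitrogen gave a 1.2-fold higher number from compound 1 to compound 2 (0.07 log units; within the scatter). The step of a 4.3-fold lower number from compound 2 to compound 3 (0.63 log units; beyond the scatter) is the only one beyond the scatter here; compound 3 has the lowest number of the three. The difference between the cores of compound 1 and compound 3 is not broken down here.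

Compound 4 `CC(C)C(C)NC1=NS(=O)(=O)c2cc(I)ccc2N1` is not yet measured. It differs from compound 3 by methyl in place of hydrogen on a saturated chain carbon bound to two saturated chain carbons, the same kind of change as from compound 1 to compound 2, though the place differs: there the carbon stands two bonds along the chain from an amine nitrogen, here it is bound to two saturated chain carbons. Because a 1.2-fold higher number from compound 1 to compound 2 (0.07 log units; within the scatter) stayed within the scatter, the step is expected to be a 1.2-fold higher number from compound 3 to compound 4 (0.09 log units; within the scatter). Compound 4 is estimated at 1.6 uM in this assay, between 0.6 uM and 4 uM.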

Compound 4, concentration for half-maximal effect: 0.94 uM
The estimate for compound 4 lay 1.7-fold (0.23 log units) above the measured number; low and high end bracket the measured number.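

In this assay, the methyl change gave a 1.4-fold lower number from compound 3 to compound 4 (0.14 log units; within the scatter), and it carries over from the core of compound 1 to the core of compound 3 without a detectable difference: the same change on two cores in this assay, a 1.2-fold higher number (0.07 log units; within the scatter) from compound 1 to compound 2 and a 1.4-fold lower number (0.14 log units; within the scatter) from compound 3 to compound 4, 1.6-fold (0.21 log units) apart, within the scatter of two such steps The two steps point in opposite directions, but both lie within the scatter, so no direction can be read from them. This rests on two pairs only, with the methyl at different places on the chain, and it does not show that the change would stay this small on another core or at another chain carbon.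

Still open, from the compounds shown here alone, is whether a longer chain or a cyclohexyl group in place of the 1,2-dimethylpropyl would keep the number in the same range. Also open, going by these compounds, is how chloro in place of iodo would behave with these chains.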